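Aryl exchange on the alkyne of a phenoxyacetic acid series

The source may report more compounds than this note shows. Statements on the series, on what has been measured and on what is new or still open speak of the compounds shown alone.

Measured compounds:
- compound 1 `CC1(O)c2ccc(C#Cc3cc(Cl)ccc3OCC(=O)O)cc2S(=O)(=O)C1(C)C`: 28 nM
- compound 2 `CC(C)(C)N1C(=O)c2ccc(C#Cc3cc(Cl)ccc3OCC(=O)O)cc2S1(=O)=O`: 14 nM
- compound 3 `O=C(O)COc1ccc(Cl)cc1C#Cc1ccc(Cl)s1`: 183 nM

All three share a phenoxyacetic acid carrying a triple bond, and all were run in an assay on CHO cells for displacement of a labelled ligand from prostaglandin D2 receptor 2 (Homo sapiens), read by scintillation counting; on this read-out higher numbers stand for weaker inhibition and lower numbers for stronger inhibition. Compound 1 gives 28 nM and compound 2 gives 14 nM. Compound 3 stands at the high end of the three numbers with 183 nM; its nearest neighbour is compound 1 and the more distant one is compound 2, both gaps lying beyond the usual scatter. No two of the measured compounds differ in only one place, so no single step can be read off directly.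

Compound 4 `O=C(O)COc1ccc(Cl)cc1C#Cc1ccc(Cl)cc1` is not yet measured. It differs from compound 3 at the far end of the triple bond only: 4-chlorophenyl in place of 5-chlorothiophen-2-yl on a triple-bonded carbon. The remainder of the molecule is unchanged.

For the measured compounds named here, with no directly comparable step available, the expectation for the change from compound 3 to compound 4 in this assay is a small shift, not clearly beyond the scatter, a 1.1-fold higher number from compound 3 to compound 4 (0.04 log units; within the scatter). Compound 4 is therefore expected to come in near 200 nM, within a range of 70 nM to 600 nM.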

Compound 4, inhibition constant: 60 nM
The estimate for compound 4 lay 3.3-fold (0.52 log units) above the measured number; measured number below the stated range.
By their numbers in this assay, from the lowest: compounds 2 and 1 (each within the scatter of the next); then compound 4; then compound 3.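

In this assay, the far end of the triple bond responds to the aromatic ring it carries: 4-chlorophenyl in place of 5-chlorothiophen-2-yl gives a 3.1-fold lower number from compound 3 to compound 4 (0.48 log units; beyond the scatter), a modest step but one beyond the scatter. The earlier compounds shown here could not show this, as none of them differed from another in one place only, so the high number of compound 3 could not be tied to any single part of its structure; this step now ties a change in that number to the ring at this position. Nothing measured here accounts for the difference between the two rings.

The compounds shown leave open what part the chlorine itself plays at this position, and whether a methoxy group or a nitrile in its place on the six-membered ring would move the number further in either direction. Also open, as far as these compounds go, is whether a plain phenyl or a pyridine ring on the triple-bonded carbon would stay close to compound 4 or fall back towards compound 3.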